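The source may report more compounds than this note shows. Statements on the series, on what has been measured and on what is new or still open speak of the compounds shown alone.

Compound 1 `O=C(CN1CCCCC1)Nc1ccc(-c2nc3cc(C(F)(F)F)ccc3[nH]2)cc1` gives 31000 nM in an ADME assay on Vero cells (Chlorocebus sabaeus) for cytotoxicity; on this read-out higher numbers stand for lower toxicity in this test and lower numbers for higher toxicity in this test.
Compound 2 `Cn1c(-c2ccc(NC(=O)CN3CCCCC3)cc2)nc2cc(C(F)(F)F)ccc21` reaches only the limit of this assay, at > 100000 nM.
Compound 3 `CC(=O)Nc1ccc(-c2nc3cc([N+](=O)[O-])ccc3[nH]2)cc1` likewise reaches only the limit of this assay, at > 100000 nM.

Among the three measured compounds, compound 1 is the only one with a number on this read-out; the other two values stand at the limit of this assay, a point noted in the limit of > 100000 nM in this assay, at which 2 of the 3 values shown sit. Among the measured compounds shown here, the one measured step that differs in a single place is an at least 3.2-fold higher number from compound 1 to compound 2 (0.50 log units; beyond the scatter), which concerns methyl in place of hydrogen on an aromatic nitrogen and therefore a different part of the molecule from the change considered here.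

Compound 4 `CCN(CC)CC(=O)Nc1ccc(-c2nc3cc(C(F)(F)F)ccc3[nH]2)cc1` differs from compound 1 by diethylamino in place of piperidin-1-yl on a saturated chain carbon bound to a carbonyl carbon. For the measured compounds named here, neither measured step touches the saturated chain carbon bound to the carbonyl carbon, so there is no direct precedent for this exchange, and piperidin-1-yl and diethylamino are both small basic amines of similar size. On that basis the account expects the number for compound 4 to stay within the scatter of compound 1, with the expected step being no change at the digits printed from compound 1 to compound 4 (within the scatter). The estimate for compound 4 is 31000 nM, with a range from 12000 nM to 80000 nM.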

Compound 4, half-maximal cytotoxic concentration: 24000 nM
Beside the measured number, compound 4's estimate is 1.3-fold (0.11 log units) above it, and the stated range covers the measured number.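

In this assay, among the compounds shown here, diethylamino in place of piperidin-1-yl on a saturated chain carbon bound to a carbonyl carbon gives a 1.3-fold lower number from compound 1 to compound 4 (0.11 log units; within the scatter), the first reading at this place, which neither earlier comparison touched. For this pair, then, replacing the six-membered non-aromatic ring with an open amine that has no ring and one heavy atom fewer does not carry the number beyond the scatter. Both compounds give real numbers rather than a limit, so this step can be read in full, unlike the step that ends at compound 2, whose value is a limit: the limit of > 100000 nM in this assay, at which 2 of the 4 values shown sit.

Going by these compounds, this remains a single pair, so it is open whether the same holds for other groups on this carbon, such as morpholin-4-yl, a primary amine or a carboxylic acid. Also open, on these data alone, is whether methyl in place of hydrogen on an aromatic nitrogen would act on compound 4 as it did on compound 1.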